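Thiourea to urea on the shared core, cytotoxicity in HEK-293T cells

The source may hold more compounds than are shown below. What is called first, only, known or untested is meant among the compounds shown, and "the series" means these compounds.

The account covers two measured compounds and one that awaits measurement. Compound 1 `O=S(=O)(NCCNC(=S)Nc1cccc(Cl)c1)c1ccc(-c2ccccc2OCc2ccccc2)s1` and compound 2 `Cc1ccc(-c2ccsc2S(=O)(=O)NCCNC(=S)Nc2ccc([N+](=O)[O-])cc2)c(Oc2ccc(O)c(O)c2)c1` share a core and were both examined in an ADME assay on HEK-293T cells (Homo sapiens) for cytotoxicity, read by CCK-8 assay, with a stated time of 48 h; a lower number here means a stronger inhibitor, a higher number a weaker inhibitor. In this assay compound 1 gives 10200 nM. Compound 2 gives 8200 nM in this assay, a number that sits apart from compound 1 by less than the usual scatter of repeated measurements, so the two compounds cannot be told apart on these figures.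

Compound 3 `Cc1ccc(-c2ccsc2S(=O)(=O)NCCNC(=O)Nc2cc(Cl)cc(Cl)c2)c(Oc2ccc(O)c(O)c2)c1` is built from compound 2 by a single change: a group of 11 heavy atoms (7 carbon, 1 nitrogen, 1 oxygen, 2 chlorine; one six-membered aromatic ring of carbon only) in place of a group of 12 heavy atoms (7 carbon, 2 nitrogen, 2 oxygen, 1 sulfur; one six-membered aromatic ring of carbon only), on an amine nitrogen. The group that leaves carries the thiourea and the nitro-bearing ring; the group that enters is the (3,5-dichlorophenyl)carbamoyl unit, placed on the same amine nitrogen whose other neighbour is a saturated chain carbon.

Among the compounds with values here, no step between measured compounds is available to gauge such a change, so the expected step from compound 2 to compound 3, a 1.3-fold higher number from compound 2 to compound 3 (0.13 log units; within the scatter), is kept small and without a clear direction, staying within the scatter. Compound 3 is therefore estimated to give about 11000 nM in this assay, with a range from 4500 nM to 28000 nM.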

Compound 3, half-maximal inhibitory concentration: 6700 nM
Compound 3: the middle estimate sits 1.6-fold (0.22 log units) above what was measured; measured number inside the range.
By their numbers in this assay, from the lowest: compounds 3, 2 and 1 (each within the scatter of the next).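

In this assay, putting the (3,5-dichlorophenyl)carbamoyl group in place of the thiourea unit with its nitro-bearing ring, on the amine nitrogen whose other neighbour is a saturated chain carbon, gives a 1.2-fold lower number from compound 2 to compound 3 (0.09 log units; within the scatter). Within the data shown here, this is the only step that can be read at this place, and it shows that this exchange, which replaces the thiourea with a urea and the nitro-bearing ring with a dichlorinated one in a single move, yields two compounds that cannot be told apart on these figures. Nothing measured alongside these numbers speaks to why the two compounds read as they do.

The sulfur-to-oxygen exchange and the exchange of ring groups arrive together in this one step, so the compounds shown do not separate what each contributes, and the two changes could in principle offset one another. Also open, as far as these compounds go, is whether a different group on that ring, such as an amine or a carboxylic acid, or a longer chain on the amine nitrogen, would move the number beyond the scatter.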